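The compounds below may be only part of what the source reports. "The series", "measured", "known", "first", "only" and "open" are said of these compounds alone.

In a functional assay on MCF7 cells (Homo sapiens) for antiproliferative activity, read by sulforhodamine B assay, with a stated time of 72 h (a higher number here means a weaker inhibitor, a lower number a stronger inhibitor), the measured compounds read:

- compound 1 `COc1ncc(-c2ccc3ncnc(Nc4cnn(CCC(=O)O)c4)c3c2)cc1NS(C)(=O)=O` gives 560 nM 
- compound 2 `COc1ncc(-c2ccc3ncnc(Nc4ccc(OCCO)nc4)c3c2)cc1NS(C)(=O)=O` gives 3080 nM 
- compound 3 `COc1ncc(-c2ccc3ncnc(Nc4ccc(OCCO)nc4)c3c2)cc1NS(=O)(=O)c1ccc(F)cc1F` gives 4300 nM 

Compound 2 lies within the scatter of compound 3 and beyond the scatter of compound 1, whose number is lower. Compound 4 `COc1ncc(-c2ccc3ncnc(Nc4cnn(CCCO)c4)c3c2)cc1NS(C)(=O)=O` puts 1-(3-hydroxypropyl)-1H-pyrazol-4-yl in place of 6-(2-hydroxyethoxy)pyridin-3-yl on a nitrogen on an aromatic ring. Most relevant is a 5.5-fold higher number from compound 1 to compound 2 (0.74 log units; beyond the scatter), the same pyridinyl group replacing 1-(2-carboxyethyl)-1H-pyrazol-4-yl. The step of a 1.4-fold higher number from compound 2 to compound 3 (0.14 log units; within the scatter) concerns the sulfonyl sulfur, which compound 4 leaves unchanged. For the measured compounds named here, no measured compound carries the 3-hydroxypropyl group, so a reversal of the first step is only a guide. The step expected in this assay is a 4.7-fold lower number from compound 2 to compound 4 (0.68 log units; beyond the scatter), towards a lower number. Compound 4 is estimated at 650 nM (expected range 170 nM to 2500 nM).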

Compound 4, half-maximal inhibitory concentration: 730 nM
Beside the measured number, compound 4's estimate is 1.1-fold (0.05 log units) below it, and the stated range covers the measured number.
By their numbers in this assay, from the lowest: compounds 1 and 4 (each within the scatter of the next); then compounds 2 and 3 (each within the scatter of the next).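

In this assay, 1-(3-hydroxypropyl)-1H-pyrazol-4-yl on the nitrogen gives a 4.2-fold lower number from compound 2 to compound 4 (0.63 log units; beyond the scatter), so the lower number against 6-(2-hydroxyethoxy)pyridin-3-yl does not depend on the carboxy group of compound 1. Hydroxymethyl in place of carboxy on the chain gives a 1.3-fold higher number from compound 1 to compound 4 (0.12 log units; within the scatter), which leaves the two chain ends undistinguished in this assay. No evidence bears on the cause of either step.

Open, going by these compounds, is how an amine in place of the hydroxymethyl would read on the same chain. Also open, on these data alone, is whether a longer chain on the five-membered ring would hold the number.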